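The source may report more compounds than this note shows. Statements on the series, on what has been measured and on what is new or still open speak of the compounds shown alone.

Compound 1 `O=C(CN1CCCC1)Nc1ccc2ncnc(Nc3cccc(Cl)c3)c2c1`, compound 2 `O=C(CN1CCCCC1)Nc1ccc2ncnc(Nc3cccc(Cl)c3)c2c1` and compound 3 `O=C(CN1CCCC1)Nc1ccc2ncnc(Nc3ccc(Br)cc3)c2c1` were all tested in a functional assay on MCF7 cells (Homo sapiens) for antiproliferative activity, read by MTT assay, with a stated time of 48 h; a higher number here means a weaker inhibitor, a lower number a stronger inhibitor. In this assay compound 1 gives only a limit, > 100000 nM. Compound 2 likewise reaches only a limit, > 100000 nM. Compound 3 too stops at a limit, > 100000 nM. The change from compound 1 to compound 2 is piperidin-1-yl in place of pyrrolidin-1-yl on a saturated chain carbon bound to a carbonyl carbon, and its step, a step that the two limits leave unreadable from compound 1 to compound 2, cannot be read, since (the limit of > 100000 nM in this assay, at which 3 of the 3 values shown sit). The two cores differ by 4-bromophenyl in place of 3-chlorophenyl on a nitrogen on an aromatic ring, with the step that the two limits leave unreadable from compound 1 to compound 3 equally unreadable. Compound 4 `O=C(CN1CCCCC1)Nc1ccc2ncnc(Nc3ccc(Br)cc3)c2c1` has not yet been measured; it arises from compound 3 by the same change, (piperidin-1-yl in place of pyrrolidin-1-yl on a saturated chain carbon bound to a carbonyl carbon). Given that compound 3 sits at > 100000 nM, the step that the limit leaves unreadable from compound 3 to compound 4 is expected to be small. Compound 4 is therefore estimated at 150000 nM in this assay.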

Compound 4, half-maximal inhibitory concentration: > 100000 nM
Compound 4 ended at the assay's limit (the forecaster's own chance of this, stated with the estimate: 85%); the middle value does not contradict the limit.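

Neither compound 4 against compound 3 nor compound 4 against compound 2 gives a readable step in this assay because every value is a limit: the limit of > 100000 nM in this assay, at which 4 of the 4 values shown sit. The compounds shown leave open how either change would act on a compound with a measurable value.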